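Sulfonamide aryl change from 3,4-difluorophenyl to 2,3-dimethylphenyl

The source may report more compounds than this note shows. Statements on the series, on what has been measured and on what is new or still open speak of the compounds shown alone.

Compound 2 `O=C1NCCN1c1ccc(S(=O)(=O)Nc2ccc(F)c(F)c2)cc1` in a functional assay on HT-29 cells (Homo sapiens) for antiproliferative activity, read by sulforhodamine B assay, with a stated time of 48 h (on this read-out higher numbers stand for weaker inhibition and lower numbers for stronger inhibition), gives 350 nM, the lowest of the two numbers shown; compound 1 `O=C1NCCN1c1ccc(S(=O)(=O)Nc2ccc(OC(F)F)cc2)cc1` sits nearest with 650 nM, a gap within the scatter. Compound 3 `O=C1NCCN1c1ccc(S(=O)(=O)Nc2ccc(C3CCCCC3)cc2)cc1` reaches only the limit (the limit of > 1000 nM in this assay, at which 1 of the 3 values shown sits), so compound 3 gives > 1000 nM and no number. The one single-point step shown, an at least 1.5-fold higher number from compound 1 to compound 3 (0.18 log units; that floor lies within the scatter), is a floor that lies within the scatter, yet it carried the compound to the limit. Compound 4 `Cc1cccc(NS(=O)(=O)c2ccc(N3CCNC3=O)cc2)c1C` differs from compound 2 by 2,3-dimethylphenyl in place of 3,4-difluorophenyl on a sulfonamide nitrogen. The step from compound 1 to compound 3 also exchanged a fluorinated aryl group for a pure hydrocarbon one and raised the number; on that single precedent the change in compound 4 is expected to move in the same direction, with a 2.0-fold higher number from compound 2 to compound 4 (0.30 log units; within the scatter) likely beyond the scatter but well short of the limit. Compound 4 is therefore estimated at 700 nM, ranging from 300 nM to 1600 nM.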

Compound 4, half-maximal inhibitory concentration: 190 nM
Compound 4: the middle estimate sits 3.7-fold (0.57 log units) above what was measured, outside the stated range (below it).
By their numbers in this assay, from the lowest: compounds 4, 2 and 1 (each within the scatter of the next, the first and the last beyond it). At a limit, above all of these: compound 3.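

In this assay, 2,3-dimethylphenyl in place of 3,4-difluorophenyl on a sulfonamide nitrogen gives a 1.8-fold lower number from compound 2 to compound 4 (0.27 log units; within the scatter) and so leaves the number within the scatter of compound 2, with no fluorine on the aryl group. Compound 3 also carries no fluorine there and gives > 1000 nM as a limit and not a number. Lack of fluorine on this aryl group therefore does not by itself put a compound at the limit. Nothing measured here gives a reason for this step.

Left open is how an amine or a carboxylic acid on this aryl group would read. Also open, on these data alone, is whether an unsubstituted phenyl reads with compound 2 and compound 4.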